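The source may hold more compounds than are shown below. What is called first, only, known or untested is meant among the compounds shown, and "the series" means these compounds.

Among the compounds with values here, in a functional assay on L1210 cells (Mus musculus) for antiproliferative activity, read by cell counting, with a stated time of 96 h (a higher number here means a weaker inhibitor, a lower number a stronger inhibitor), compound 1 (`CC(Nc1ccccc1Oc1ccccc1)=C1C(=O)CC(c2ccccc2)CC1=O`) gives 86 nM, while compound 2 (`COc1cc(Oc2ccccc2NC(C)=C2C(=O)CC(c3ccccc3)CC2=O)ccc1N`) gives 26 nM, the lower of the two numbers so far. Compound 3 (`CC(Nc1ccccc1Oc1ccc(N)cc1)=C1C(=O)CC(c2ccccc2)CC1=O`) has not yet been measured. It differs from compound 2 by hydrogen in place of methoxy on an aromatic carbon, ortho to an amino group and meta to a large group: hydrogen in place of methoxy on an aromatic carbon. Within the data shown here, only one measured step bears on this change: a 3.3-fold lower number from compound 1 to compound 2 (0.52 log units; beyond the scatter), where 4-amino-3-methoxyphenyl replaces phenyl. That step brought in the amino and methoxy groups together, and the data do not show how it divides between them. Compound 3 keeps the amino group, so it is expected to give back only part of that step, towards a higher number in this assay. The expected change is a 1.5-fold higher number from compound 2 to compound 3 (0.19 log units; within the scatter). The estimate for compound 3 is 40 nM, with an expected range of 15 nM to 110 nM.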

Compound 3, half-maximal inhibitory concentration: 40 nM
For compound 3 middle estimate and measured number coincide at the digits printed; low and high end bracket the measured number.
By their numbers in this assay, from the lowest: compounds 2 and 3 (each within the scatter of the next); then compound 1.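

In this assay the amino group on its own gives a 2.2-fold lower number from compound 1 to compound 3 (0.33 log units; beyond the scatter), so most of the earlier gain from 4-amino-3-methoxyphenyl can now be placed on that group. Replacing the methoxy group with hydrogen on this aromatic carbon, ortho to the amino group, gives a 1.5-fold higher number from compound 2 to compound 3 (0.19 log units; within the scatter), so with the amino group present the methoxy group makes no difference that can be told apart from the scatter. Nothing available here explains either step.

Going by these compounds, it remains open whether a methoxy group on this carbon would shift the number with no amino group on the ring. On these data alone, it is also open whether a hydroxyl group or a dimethylamino group in place of the amino group would keep the step seen with the amino group.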